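Cytotoxicity notes on the step to compound 4

The source may hold more compounds than are shown below. What is called first, only, known or untested is meant among the compounds shown, and "the series" means these compounds.

Values so far in an ADME assay on L6 cells (Rattus norvegicus) for cytotoxicity, read by resazurin assay, with a stated time of 70 h (a higher number here means a weaker inhibitor, a lower number a stronger inhibitor), are as follows
- compound 1 `CC1=CC(C)(C)N(Cc2ccc(C)cc2)c2ccc(O)cc21` at 8100 nM
- compound 2 `COc1ccc(CN2c3ccc(O)cc3C(C)=CC2(C)C)cc1` at 6200 nM
- compound 3 `CC(=O)Oc1ccc2c(c1)C(C)=CC(C)(C)N2Cc1ccc(C#N)cc1` at 29000 nM

Compound 3 carries the highest number of the three in this assay and its gap to each of the other two lies beyond the scatter. The next compound, compound 4 `COc1cccc(CN2c3ccc(OC(C)=O)cc3C(C)=CC2(C)C)c1`, has 3-methoxyphenyl in place of 4-cyanophenyl on a saturated chain carbon bound to a nitrogen on an aromatic ring in a ring. Among the compounds with values here, the only measured step, a 1.3-fold lower number from compound 1 to compound 2 (0.12 log units; within the scatter), exchanges methyl for methoxy on an aromatic carbon and bears on this change only loosely. Within the data shown here, no measured step removes the 4-cyanophenyl, so the evidence is thin. A modest move toward compound 2 at 6200 nM is expected, with wide uncertainty. The expected step is a 1.9-fold lower number from compound 3 to compound 4 (0.29 log units; within the scatter) and it may yet prove to lie within the scatter. For compound 4 the estimated value is 15000 nM (expected range 6000 nM to 40000 nM).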

Compound 4, half-maximal inhibitory concentration: 29000 nM
For compound 4 the middle estimate is 1.9-fold (0.29 log units) below the measured one, within the range that was stated.
By their numbers in this assay, from the lowest: compounds 2 and 1 (each within the scatter of the next); then compounds 3 and 4 (each within the scatter of the next).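

In this assay, exchanging the whole aryl group at this position, on a saturated chain carbon bound to a nitrogen on an aromatic ring in a ring, gives no change at the digits printed from compound 3 to compound 4 (within the scatter). The earlier step, a 1.3-fold lower number from compound 1 to compound 2 (0.12 log units; within the scatter), changed only a single substituent on that aryl group, whereas this pair shows that the nitrile can leave and a methoxy can enter on the ring with no readable shift in this assay, a finding that holds for this pair alone. Nothing at hand offers an explanation for this outcome.

Going by these compounds, it remains open whether the result would hold for an amine, a carboxylic acid or a longer chain in place of the 3-methoxyphenyl. On these data alone, it is equally open whether 3-methoxyphenyl and 4-cyanophenyl would stay level on the core of compound 1.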